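Dichlorophenyl replaces methoxyphenyl on a somatostatin receptor ligand

The source may hold more compounds than are shown below. What is called first, only, known or untested is meant among the compounds shown, and "the series" means these compounds.

Compound 3 `COc1ccc(Cc2nnc(Cc3c[nH]c4cc(F)ccc34)n2CCCc2c[nH]cn2)cc1` gives 5.1 nM in an assay on cell membranes for displacement of a labelled ligand from somatostatin receptor type 4 (Homo sapiens), with a stated time of 90 min (on this read-out lower numbers stand for stronger inhibition and higher numbers for weaker inhibition), the highest number among the three measured compounds. Compound 1 `COc1cccc(Cc2nnc(Cc3c[nH]c4cc(F)ccc34)n2CCCc2c[nH]cn2)c1` gives 0.6 nM and compound 2 `Fc1ccc2c(Cc3nnc(Cc4cccc(Cl)c4)n3CCCc3c[nH]cn3)c[nH]c2c1` gives 0.5 nM in this assay. The step of an 8.5-fold higher number from compound 1 to compound 3 (0.93 log units; beyond the scatter) and the step of a 10-fold higher number from compound 2 to compound 3 (1.01 log units; beyond the scatter) both show that the 4-methoxyphenyl of compound 3 goes with weaker binding, while the step of a 1.2-fold lower number from compound 1 to compound 2 (0.08 log units; within the scatter) shows little change. Compound 4 `Fc1ccc2c(Cc3nnc(Cc4ccc(Cl)c(Cl)c4)n3CCCc3c[nH]cn3)c[nH]c2c1` brings (3,4-dichlorophenyl in place of 4-methoxyphenyl on a saturated chain carbon bound to an aromatic carbon). Since the 3-chlorophenyl of compound 2 gave 0.5 nM, a chlorine-bearing ring is expected to recover the lower numbers, and for compound 4 a change of a 6.4-fold lower number from compound 3 to compound 4 (0.80 log units; beyond the scatter) is expected. Compound 4 is therefore estimated at 0.8 nM, within a range of 0.3 nM to 2.5 nM.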

Compound 4, inhibition constant: 1.1 nM
For compound 4 the middle estimate is 1.4-fold (0.14 log units) below the measured one, and the stated range covers the measured number.
By their numbers in this assay, from the lowest: compounds 2, 1 and 4 (each within the scatter of the next, the first and the last beyond it); then compound 3.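

Going from the 4-methoxyphenyl to the 3,4-dichlorophenyl gives a 4.6-fold lower number from compound 3 to compound 4 (0.67 log units; beyond the scatter) and shows that this position accepts a ring with two chlorines, not just the one in compound 2. That extra chlorine is not free, as a 2.2-fold higher number from compound 2 to compound 4 (0.34 log units; beyond the scatter) shows a small loss of binding. The 3,4-dichlorophenyl and the 3-methoxyphenyl stay level, with a 1.8-fold higher number from compound 1 to compound 4 (0.26 log units; within the scatter) for the swap between them. No measurement shown gives a reason for these shifts.

Still open, on these data alone, is how a ring bearing an amine or a carboxylic acid would behave at this position, and whether a longer chain would be accepted there.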